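The source may report more compounds than this note shows. Statements on the series, on what has been measured and on what is new or still open speak of the compounds shown alone.

Working notes on the series. The shared core appears in compound 1 `CC(=O)c1c(C)c2ccc(Nc3nccc(-c4cccnc4)n3)cc2oc1=O`, compound 2 `COc1cc(F)ccc1-c1nc(Nc2ccc3c(N4CCN(C)CC4)c(C(C)=O)c(=O)oc3c2)ncc1Cl` and compound 3 `COc1ccccc1-c1cc(Nc2ccc3c(C)c(C(C)=O)c(=O)oc3c2)ncn1`. In a functional assay on MV4-11 cells (Homo sapiens) for inhibition, read by luminescence and CellTiter-Glo, with a stated time of 72 h (a higher number here means a weaker inhibitor, a lower number a stronger inhibitor), compound 1 gives 12900 nM. In this assay compound 2 gives 1390 nM. For compound 3 this assay reports only a limit, > 10000 nM; one of the three values sits at that limit (the limit of > 10000 nM in this assay, at which 1 of the 3 values shown sits). Of the two numbers given, compound 2 gives the lowest, and the gap to compound 1 is beyond the scatter.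

Compound 4 `COc1cc(F)ccc1-c1nc(Nc2ccc3c(N4CCN(C)CC4)c(C(C)=O)c(=O)oc3c2)ncc1F` has not yet been measured in this assay. It differs from compound 2 in one place: fluoro in place of chloro on an aromatic carbon, on an aromatic carbon of a six-membered aromatic ring with two nitrogens, ortho to the 4-fluoro-2-methoxyphenyl group (fluoro in place of chloro on an aromatic carbon). For the measured compounds named here, no pair of measured compounds shows this change, so the step cannot be read from the numbers given. The halogen swap is small, and the expectation is a modest rise in the number, in the direction of a weaker inhibitor, possibly not beyond the scatter. The step from compound 2 to compound 4 is expected to be a 2.2-fold higher number from compound 2 to compound 4 (0.33 log units; beyond the scatter). Compound 4 is estimated to give 3000 nM in this assay, within a range from 1200 nM to 8000 nM.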

Compound 4, half-maximal inhibitory concentration: 400 nM
Compound 4: middle estimate off by 7.5-fold (0.88 log units), on the high side; measured number outside the range, below it.
By their numbers in this assay, from the lowest: compound 4; then compound 2; then compound 1.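

In this assay, for the compounds shown here, the change from chloro to fluoro gives a 3.5-fold lower number from compound 2 to compound 4 (0.54 log units; beyond the scatter), the first step that can be read at a single position. The position, on an aromatic carbon of the six-membered aromatic ring with two nitrogens and ortho to the 4-fluoro-2-methoxyphenyl group, therefore responds to the exchange of one halogen for another, although one heavy atom replaces one heavy atom, neither group carries a hydrogen-bond donor or acceptor, and neither carries a net charge. Nothing measured for these compounds accounts for the size or direction of this step.

On these data alone, this single pair gives only two points at the position, so it does not show whether the number follows any trend across substituents there, and what a hydrogen, a methyl, a nitrile or a trifluoromethyl group would give remains open. As far as these compounds go, compounds 1 and 3 differ from compound 2 in more than one place, so whether the step would hold with the rest of the molecule changed also remains open.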